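A few compounds are considered here, and "the series" means these few. Any claim that something is new, unique, unknown or untested is made for them only; others in the source may bear on it.

Measured so far in a functional assay on NCI-H292 cells (Homo sapiens) for cytotoxicity, read by MTT assay, with a stated time of 72 h, tested at 2.5 ug/mL; on this read-out higher numbers stand for more inhibition of growth at the one concentration tested and lower numbers for less inhibition of growth:

- compound 1, `O=C1NC(=S)/C(=C/c2ccc(Br)cc2)S1`: 1.19%
- compound 2, `O=C1NC(=S)/C(=C/c2cccc(Br)c2)S1`: 11.1%
- compound 3, `O=C1NC(=S)/C(=C/c2ccccc2F)S1`: 7.78%

All three share one core and differ only in the halogen on the attached benzene ring. In this assay compound 1 gives 1.19%, the lowest of the three numbers. Its nearest neighbour is compound 3, whose number is higher by an amount that stays within the usual scatter of repeated measurements, and the furthest is compound 2, whose number is also higher by an amount within that scatter. So the three compounds cannot be told apart on these readings: each shows only slight inhibition of growth at the single concentration tested.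

The next compound, compound 4, `O=C1NC(=S)/C(=C/c2ccc(Cl)cc2)S1`, is reached from compound 1 by a single change: chloro in place of bromo on an aromatic carbon. For the measured compounds named here, no change between two measured compounds has been characterised here, so there is no measured step to lean on. With every neighbour of compound 1 sitting within the scatter of its own number, the expectation for compound 4 is a step of about none beyond the scatter in this assay, in either direction. For compound 4 the estimated value is 5%, within a range from -5% to 15%, which means an expected step of a number 3.8 percentage points higher from compound 1 to compound 4 (within the scatter).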

Compound 4, percent growth inhibition at one concentration: 28.6%
Compound 4: the middle estimate sits 23.6 percentage points below what was measured; the whole stated range lies below it.
By their numbers in this assay, from the lowest: compounds 1, 3 and 2 (each within the scatter of the next); then compound 4.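

In this assay the exchange of bromo for chloro gives a number 27.4 percentage points higher from compound 1 to compound 4 (beyond the scatter) and is the first step among these compounds to lie beyond the usual scatter. It shows that the read-out can respond to a change at this position, the aromatic carbon para to a group of 8 heavy atoms, even though the shared core stays the same. The change is also a small one on paper, since one halogen atom replaces another and neither group brings a ring, a hydrogen-bond donor or acceptor, or a net charge, and nothing at hand explains why this exchange gives such a step.

Still open, from the compounds shown here alone, is whether the higher number belongs to chloro in particular, or whether other groups on this same carbon, such as fluoro, methoxy or an amine, would give readings closer to compound 4 or to compound 1. Going by these compounds, because the reading comes from one concentration only, it also remains open how compound 4 would behave across a range of concentrations.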